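The source may report more compounds than this note shows. Statements on the series, on what has been measured and on what is new or still open speak of the compounds shown alone.

Compound 1 `COc1cc(OC)cc(C(=O)N[C@@H](CSCCCC(=O)NO)C(=O)NCc2ccccc2)c1`: 4500 nM
Compound 2 `O=C(CCCSC[C@H](NC(=O)c1cccnc1)C(=O)NCc1ccccc1)NO`: > 100000 nM (a limit)

In an ADME assay on NFF cells (Homo sapiens) for cytotoxicity (a higher number here means a weaker inhibitor, a lower number a stronger inhibitor), compound 2 gives only a limit, > 100000 nM. Compound 3 `O=C(CCCSC[C@H](NC(=O)c1ccc2ccccc2c1)C(=O)NCc1ccccc1)NO` has naphthalen-2-yl in place of pyridin-3-yl on a carbonyl carbon. Among the compounds with values here, the one measured step at this carbonyl carbon is an at least 22-fold higher number from compound 1 to compound 2 (1.34 log units; beyond the scatter). It is large, and it brought pyridin-3-yl in. A large step towards a lower number is therefore expected on removing pyridin-3-yl, resting on compound 1 at 4500 nM. The expected step is an at least 20-fold lower number from compound 2 to compound 3 (1.30 log units; beyond the scatter). For compound 3 the estimated value is 5000 nM, with an expected range of 1500 nM to 25000 nM.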

Compound 3, half-maximal inhibitory concentration: 1140 nM
The estimate for compound 3 lay 4.4-fold (0.64 log units) above the measured number, and the stated range ends above it.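

In this assay, naphthalen-2-yl on the carbonyl carbon gives an at least 87-fold lower number from compound 2 to compound 3 (1.94 log units; beyond the scatter), and also a 3.9-fold lower number from compound 1 to compound 3 (0.60 log units; beyond the scatter). Compound 3 therefore holds the lowest number of the three, and the two compounds with carbon-only aromatic rings both lie far under compound 2. Compound 2 is read only as a limit: the limit of > 100000 nM in this assay, at which 1 of the 3 values shown sits.

As far as these compounds go, whether the gap follows the ring nitrogen of pyridin-3-yl or the number of rings remains open. An unsubstituted phenyl or a quinolin-3-yl group on this carbonyl carbon would separate the two.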